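The source may report more compounds than this note shows. Statements on the series, on what has been measured and on what is new or still open speak of the compounds shown alone.

Compound 1 `O=C(/C=C/c1cccnc1)NCCCCCCc1ccc(S(=O)(=O)Nc2ccccc2)cc1` gives 36 nM in a functional assay on MCF7 cells (Homo sapiens) for inhibition, read by CCK-8 assay, with a stated time of 72 h; a higher number here means a weaker inhibitor, a lower number a stronger inhibitor.
Compound 2 `Cc1cccc(NS(=O)(=O)c2cccc(CCCCCCNC(=O)/C=C/c3cccnc3)c2)c1` gives 4 nM in this assay.

For the measured compounds named here, of these two numbers compound 2 has the lower one, and compound 1, the only other compound, lies well beyond the scatter above it. Compound 3 `O=C(/C=C/c1cccnc1)NCCCCCCc1cccc(S(=O)(=O)Nc2ccc(C(F)(F)F)cc2)c1` differs from compound 2 in one place: 4-(trifluoromethyl)phenyl in place of 3-methylphenyl on a sulfonamide nitrogen. Going by the values given here, no measured pair shows this change, so its size cannot be read from the data. A small loss is expected, the step of a 2.0-fold higher number from compound 2 to compound 3 (0.30 log units; within the scatter), with a wide range around it. In this assay compound 3 is expected to give about 8 nM, from 2 nM to 40 nM.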

Compound 3, half-maximal inhibitory concentration: 67.8 nM
The estimate for compound 3 lay 8.5-fold (0.93 log units) below the measured number; measured number above the stated range.
By their numbers in this assay, from the lowest: compound 2; then compounds 1 and 3 (each within the scatter of the next).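

The phenyl group on the sulfonamide nitrogen is not a freely exchangeable part of the molecule: in this assay, 4-(trifluoromethyl)phenyl in place of 3-methylphenyl gives a 17-fold higher number from compound 2 to compound 3 (1.23 log units; beyond the scatter), a large loss. For the compounds shown here, this is the first pair that differs in one place only, so it is the first direct sign that this group strongly affects the number. No available evidence explains the loss.

The change alters both the ring's substituent and its numbered place, and this one pair cannot separate the two. From the compounds shown here alone, how a chlorine atom or a methoxy group on this ring would fare also stays open.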